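Ethyl for methyl on the benzimidazole nitrogen

The source may report more compounds than this note shows. Statements on the series, on what has been measured and on what is new or still open speak of the compounds shown alone.

Measured compounds:
Compound 1, `CCn1c(/C=C2\SC(=O)N(CC(=O)Nc3cc(C(C)(C)C)on3)C2=O)nc2ccccc21`, in a functional assay on MDA-MB-231 cells (Homo sapiens) for inhibition, read by MTT assay, with a stated time of 48 h (a higher number here means a weaker inhibitor, a lower number a stronger inhibitor), gives > 50000 nM, a limit of the assay.
Compound 2, `Cn1c(/C=C2\SC(=O)N(CC(=O)Nc3nc(-c4ccccc4)cs3)C2=O)nc2ccccc21`, in this assay gives 29200 nM.

Going by the values given here, compound 2 is the only compound among the two with a number in this assay; the other value is a limit, as the limit of > 50000 nM in this assay, at which 1 of the 2 values shown sits, records for compound 1. Compound 3, `CCn1c(/C=C2\SC(=O)N(CC(=O)Nc3nc(-c4ccccc4)cs3)C2=O)nc2ccccc21`, has not yet been measured in this assay. It differs from compound 2 in one place: methyl in place of hydrogen on a saturated chain carbon bound to an aromatic nitrogen. Among the compounds with values here, no step between measured compounds shares this change, so nothing measured speaks to its size. The added carbon is small and sits away from the amide and the thiazole, so the account expects no step beyond the scatter of this assay in either direction. For compound 3 the estimated step from compound 2 is a 1.0-fold higher number from compound 2 to compound 3 (0.01 log units; within the scatter). Compound 3 is therefore estimated at 30000 nM in this assay, with an expected range from 12000 nM to 80000 nM.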

Compound 3, half-maximal inhibitory concentration: > 50000 nM
Compound 3: only a limit was reported (the forecaster's own chance of this, stated with the estimate: 30%); middle value at least 1.6-fold (0.22 log units) from the limit.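

Going by these compounds alone, this is the first step in this assay at this position: going from 1-methyl-1H-benzimidazol-2-yl to 1-ethyl-1H-benzimidazol-2-yl gives an at least 1.7-fold higher number from compound 2 to compound 3 (0.23 log units; that floor lies within the scatter). The step is only a floor and that floor lies within the scatter, so the added methyl on a saturated chain carbon bound to an aromatic nitrogen is not shown to change the read-out by more than repeat measurements would, though the real step may be larger. The step that exchanges 5-(tert-butyl)-1,2-oxazol-3-yl for 4-phenyl-1,3-thiazol-2-yl on the amide-type nitrogen cannot be read, and most of the set now rests on a limit rather than on a number: the limit of > 50000 nM in this assay, at which 2 of the 3 values shown sit.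

From the compounds shown here alone, how far compound 3 really lies from compound 2 stays open, as compound 3 has only a limit. The compounds shown also do not tell how a longer chain such as propyl, or a chain ending in an amine or a carboxylic acid, would read at this position in this assay.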